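Swapping Nitrophenyl for Dichlorophenyl: Expected Cytotoxicity of Compound 4

This account rests on a few compounds, and the source may have more. Where it says the series, first, only, none or still open, it means among the compounds named here.

Compound 1 `O=C1c2ccccc2C(=O)N1CCOC(=S)N(C(=O)c1ccc([N+](=O)[O-])cc1)c1ccc(Cl)cc1` was tested in an ADME assay on MT4 cells (Homo sapiens) for cytotoxicity, read by MTT assay; on this read-out higher numbers stand for lower toxicity in this test and lower numbers for higher toxicity in this test. For compound 1 the read-out reached the limit of the test, > 100000 nM, so only a limit and not a number is known; this is the limit of > 100000 nM in this assay, at which 1 of the 3 values shown sits. Compound 2 `Cc1ccc(N(C(=O)c2ccc([N+](=O)[O-])cc2)C(=S)OCCN2C(=O)c3ccccc3C2=O)cc1` gives 58000 nM in the same test, and compound 3 `O=C1c2ccccc2C(=O)N1CCOC(=S)N(C(=O)c1ccc(Cl)c([N+](=O)[O-])c1)c1ccccc1` gives 51000 nM. Among the compounds with values here, the one measured step that changes a single place, an at least 1.7-fold lower number from compound 1 to compound 2 (0.23 log units; that floor lies within the scatter), lowers the number, but its floor lies within the usual scatter, so it shows no clear effect.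

Compound 4 `O=C1c2ccccc2C(=O)N1CCOC(=S)N(C(=O)c1cc(Cl)cc(Cl)c1)c1ccc(Cl)cc1` differs from compound 1 in one place: 3,5-dichlorophenyl in place of 4-nitrophenyl on a carbonyl carbon. Within the data shown here, no measured step concerns this exchange of the group on the carbonyl carbon. Compound 3 carries both chloro and nitro on that ring, but it differs from compound 1 in a second place as well, so only its value stands beside the others for comparison.

All three measured values sit in a region of high numbers, that is, low toxicity in this test, and compound 1 sits at the limit. Compound 4 is expected to stay in that region, so the estimated step of an at least 1.2-fold lower number from compound 1 to compound 4 (0.09 log units; that floor lies within the scatter) is expected to be small. The estimate for compound 4 is 80000 nM, with a range from 30000 nM to 200000 nM.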

Compound 4, half-maximal cytotoxic concentration: 32000 nM
The estimate for compound 4 lay 2.5-fold (0.40 log units) above the measured number; the range from low to high includes it.
By their numbers in this assay, from the lowest: compounds 4, 3 and 2 (each within the scatter of the next). At a limit, above all of these: compound 1.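

Among the compounds shown, the exchange of 4-nitrophenyl for 3,5-dichlorophenyl on a carbonyl carbon whose other neighbour is an amide-type nitrogen is the only change at this place with a readable size, and in this assay it gives an at least 3.1-fold lower number from compound 1 to compound 4 (0.49 log units; beyond the scatter). The earlier single change, methyl in place of chloro on an aromatic carbon, had a floor that stayed within the scatter, whereas this one clears it, so the group on the carbonyl carbon is a place where a single exchange can measurably shift the number towards higher toxicity in this test. As far as these compounds go, the step can be given only as a floor because compound 1 stands at a limit, so the full size of the change remains unknown: the limit of > 100000 nM in this assay, at which 1 of the 4 values shown sits.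

The compounds shown do not tell whether the step comes from losing the nitro group or from gaining the two chloro groups, and compound 3 differs from compound 1 in a second place, so it cannot separate the two. Also open, from the compounds shown here alone, is how the number would move with an amine or a carboxylic acid on this ring, or with a longer chain in place of the ring.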